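A few compounds are considered here, and "the series" means these few. Any claim that something is new, unique, unknown or untested is made for them only; others in the source may bear on it.

Series notes, step from compound 2 to compound 4.

Compound 2 `CCOC(=O)C1=C(C)NC(C)=C(C(=O)OCC)C1c1c(-c2ccc([N+](=O)[O-])cc2)nc2sc(Cl)cn12` holds the highest of the three numbers in hand in an ADME assay on Right cardiac atrium (Cavia porcellus); on this read-out lower numbers stand for an effect already at smaller amounts and higher numbers for an effect only at larger amounts of compound: compound 2 gives 2170 nM. Its nearest neighbour is compound 3 `CCOC(=O)C1=C(C)NC(C)=C(C(=O)OCC)C1c1c(-c2ccc([N+](=O)[O-])cc2)nc2sc(F)cn12`, which in this assay gives 77 nM; the furthest is compound 1 `CCOC(=O)C1=C(C)NC(C)=C(C(=O)OCC)C1c1c(-c2ccc(Cl)cc2)nc2sccn12`, which in this assay gives 19 nM. Among the compounds with values here, the only single-point step measured so far, a 28-fold lower number from compound 2 to compound 3 (1.45 log units; beyond the scatter), concerns the five-membered ring of the fused system and not the pendant aryl. Within the data shown here, compound 1 and compound 2 differ in two places at once, so their values show only that the pair spans a wide gap, not what either change contributes on its own.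

Compound 4 `CCOC(=O)C1=C(C)NC(C)=C(C(=O)OCC)C1c1c(-c2cc([N+](=O)[O-])c(Cl)cc2Cl)nc2sc(Cl)cn12` is obtained from compound 2 by the change (2,4-dichloro-5-nitrophenyl in place of 4-nitrophenyl on an aromatic carbon). Among the measured compounds shown here, no measured step in this set touches the pendant aryl, so the direction of the step in this assay is open; compound 2 already sits at the high end of the series, and a 28-fold lower number from compound 2 to compound 3 (1.45 log units; beyond the scatter) shows that a single change can move the read-out a long way, so the range given is wide. Compound 4 is expected to give about 1500 nM, within 300 nM to 8000 nM. That estimate corresponds to a 1.4-fold lower number from compound 2 to compound 4 (0.16 log units; within the scatter), a step expected to stay within the scatter.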

Compound 4, half-maximal effective concentration: 220 nM
Compound 4: the middle estimate sits 6.8-fold (0.83 log units) above what was measured, and the stated range ends above it.
By their numbers in this assay, from the lowest: compound 1; then compound 3; then compound 4; then compound 2.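

In this assay, within the data shown here, the pendant aryl turns out to matter: a 9.9-fold lower number from compound 2 to compound 4 (0.99 log units; beyond the scatter), with the chloro on the five-membered ring of the fused system left in place, and this direction could not be read from the earlier compounds. Set beside a 28-fold lower number from compound 2 to compound 3 (1.45 log units; beyond the scatter), this shows that single changes at two separate places each lower the number from compound 2, so neither the chloro on the fused system nor the 4-nitrophenyl alone fixes the high value of compound 2. No measurement on hand bears on why the 2,4-dichloro-5-nitrophenyl swap has this effect.

Going by these compounds, the step bundles the two added chlorine atoms with the changed place of the nitro group, so the share of each stays open, as does whether the fluoro and the 2,4-dichloro-5-nitrophenyl changes would add up on one compound. Also open, on these data alone, is how this aromatic carbon would take a pendant aryl carrying an amine or a carboxylic acid instead of the nitro group.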